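The compounds below may be only part of what the source reports. "The series", "measured", "known", "first", "only" and "open" are said of these compounds alone.

Compound 3 `CCOC(=O)C1=C(C)NC(C)=C(C(=O)OCC)C1c1ccc(OCC(=O)NNC(=O)c2ccsc2Cl)cc1` is the second highest of the three measured compounds in a functional assay on the whole organism (strain Wistar) for inhibition, with Rattus norvegicus as the target, read by paw edema, with stated times of 30 min and 1 h, at a dose of 20 mg/kg; on this read-out higher numbers stand for more inhibition at the one dose given (going by the name of the read-out) and lower numbers for less inhibition: compound 3 gives 42.3%, compound 2 `CCOC(=O)C1=C(C)NC(C)=C(C(=O)OCC)C1c1ccc(OCC(=O)Nc2nc3ccccc3s2)cc1` gives 54.5%, and compound 1 `CCOC(=O)C1=C(C)NC(C)=C(C(=O)OCC)C1c1ccc(OCC(=O)NCc2ccccc2)cc1` gives 16.1%. The steps of a number 12.2 percentage points lower from compound 2 to compound 3 (beyond the scatter) and a number 26.2 percentage points higher from compound 1 to compound 3 (beyond the scatter) both change the group on the amide-type nitrogen. Compound 4 `CCOC(=O)C1=C(C)NC(C)=C(C(=O)OCC)C1c1ccc(OCC(=O)NNC(=O)CCC(=O)O)cc1` differs from compound 3 elsewhere: 2-carboxyethyl in place of 2-chlorothiophen-3-yl on a carbonyl carbon. For the measured compounds named here, no measured step touches that carbonyl carbon, so the measured steps bear only loosely on this change, and the direction is uncertain. A ring leaves and no ring enters, which in the step from compound 1 to compound 2 accompanied a large rise, so a decrease is expected, a number 12.3 percentage points lower from compound 3 to compound 4 (beyond the scatter), with compound 4 estimated at 30%, between 12% and 48%.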

Compound 4, a percentage reported as inhibition, in the whole organism at one dose (the size of the read-out at that dose, not a potency): 43%
Beside the measured number, compound 4's estimate is 13 percentage points below it; the range from low to high includes it.
By their numbers in this assay, from the lowest: compound 1; then compounds 3 and 4 (each within the scatter of the next); then compound 2.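

In this assay, putting 2-carboxyethyl on the carbonyl carbon in place of 2-chlorothiophen-3-yl gives a number 0.7 percentage points higher from compound 3 to compound 4 (within the scatter), so at this position a ring leaves and no ring enters with no change beyond the scatter. The open chain also keeps the gain over benzyl, with a number 26.9 percentage points higher from compound 1 to compound 4 (beyond the scatter), and the gap to 1,3-benzothiazol-2-yl, with a number 11.5 percentage points lower from compound 2 to compound 4 (beyond the scatter). No measurement at hand explains why the ring and the chain read alike.

As far as these compounds go, whether an amine, a longer chain or the ethyl ester of this carboxylic acid on the same carbonyl carbon would read alike stays open.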